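Notes on the remote substituent and acid dissociation

This account rests on a few compounds, and the source may have more. Where it says the series, first, only, none or still open, it means among the compounds named here.

Measured so far:
compound 1: `COc1cccc(Oc2ccc3c(NCCCNCc4cccc(OC)c4O)ccnc3c2)c1`, 9.28
compound 2: `COc1cccc(CNCCCNc2ccnc3cc(-c4ccccc4)ccc23)c1O`, 9.47
compound 3: `COc1cccc(CNCCCNc2ccnc3cc(Cc4ccc(C#N)cc4)ccc23)c1O`, 9.47

In a physicochemical assay for acid dissociation, compound 3 sits level with compound 2, no change at the digits printed from compound 2 to compound 3 (within the scatter), and its gap to compound 1 is also inside the scatter, a number 0.19 log units higher from compound 1 to compound 3 (within the scatter). Going by the values given here, no compound of the three can be set apart from the others on these numbers.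

Compound 4 is `COc1cccc(CNCCCNc2ccnc3cc(CC4CCCCC4)ccc23)c1O`. The change from compound 3 is cyclohexyl in place of 4-cyanophenyl on a saturated chain carbon bound to an aromatic carbon. The three measured steps all exchange the group on the aromatic carbon of the shared core, the same region that is altered here one bond further out, and none of them moved the read-out beyond the scatter: a number 0.19 log units higher from compound 1 to compound 2 (within the scatter), a number 0.19 log units higher from compound 1 to compound 3 (within the scatter), no change at the digits printed from compound 2 to compound 3 (within the scatter). The groups that come and go in this series are remote from the part of the molecule that the three measured compounds keep in common, and that common part is what all three values reflect.

The step from compound 3 to compound 4 is therefore expected to be no change at the digits printed from compound 3 to compound 4 (within the scatter). Compound 4 is expected to give 9.47, with a range from 9.15 to 9.8.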

Compound 4, acid dissociation constant: 9.47
The estimate for compound 4 equals the measured number at the digits printed, and the stated range covers the measured number.
By their numbers in this assay, from the lowest: compounds 1, 2, 3 and 4 (each within the scatter of the next).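

In this assay, cyclohexyl in place of 4-cyanophenyl gives no change at the digits printed from compound 3 to compound 4 (within the scatter), so an aromatic ring of carbon only and its nitrile can leave for a non-aromatic ring of carbon only with the read-out staying within the scatter. Read at the aromatic carbon of the shared core, the cyclohexylmethyl group agrees with this, with no change at the digits printed from compound 2 to compound 4 (within the scatter) and a number 0.19 log units higher from compound 1 to compound 4 (within the scatter), which extends the earlier picture from aromatic groups to a non-aromatic one at this place. No supporting evidence accompanies these numbers, so they stand as observations without an explanation.

Going by these compounds, whether an amine or a carboxylic acid on that aromatic carbon would also stay within the scatter remains open. On these data alone, all four compounds keep the rest of the molecule in common, so the outcome of a change there, such as a longer chain, also remains open.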